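Swapping an Aryl Group: From Compound 1 to Compound 4

This account rests on a few compounds, and the source may have more. Where it says the series, first, only, none or still open, it means among the compounds named here.

Measured compounds:
compound 1, `COc1ccccc1-c1ncnn1-c1cc(OC)c(OC)c(OC)c1`, > 10000 nM
compound 2, `COc1cc(-c2ncnn2-c2cccc([N+](=O)[O-])c2)cc(OC)c1OC`, > 10000 nM
compound 3, `COc1cc(-c2ncnn2-c2ccc([N+](=O)[O-])cc2)cc(OC)c1OC`, > 10000 nM

Of the compounds shown here, three built on one shared core have been tested in a functional assay on MCF7 cells (Homo sapiens) for antiproliferative activity, read by MTT assay, with a stated time of 72 h; a higher number here means a weaker inhibitor, a lower number a stronger inhibitor. Compound 1 gives > 10000 nM, which is a limit of the assay and not a measured number. Compound 2 also reaches only the limit, with > 10000 nM. Compound 3 likewise sits at the limit, with > 10000 nM. All three therefore stand on the same footing: the limit of > 10000 nM in this assay, at which 3 of the 3 values shown sit. None can be ranked against another, and compound 1 is as weak as this assay can record.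

Compound 4, `COc1cc(-n2ncnc2-c2ccc(Cl)cc2)cc(OC)c1OC`, has not yet been measured. It differs from compound 1 in one place: 4-chlorophenyl in place of 2-methoxyphenyl on an aromatic carbon. Among the compounds with values here, no measured step exists to guide an expectation of size or direction, because the limit of > 10000 nM in this assay, at which 3 of the 3 values shown sit, leaves nothing to compare. The step from compound 1 to compound 4 is therefore expected to be a step that the limit leaves unreadable from compound 1 to compound 4, that is, none beyond the scatter. Compound 4 is expected to give about 15000 nM in this assay, within a range from 4000 nM to 60000 nM, and most likely again only a limit.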

Compound 4, half-maximal inhibitory concentration: > 10000 nM
Compound 4 ended at the assay's limit; the forecaster's own chance of this, stated with the estimate: 70%; the middle value lies beyond the limit too.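

No step can be read between compound 1 and compound 4, because each gives a limit of the assay and not a number: the limit of > 10000 nM in this assay, at which 4 of the 4 values shown sit.

The compounds shown leave open whether 4-chlorophenyl in place of 2-methoxyphenyl changes antiproliferative activity at all, and which change to the shared core, if any, would give a measurable value.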